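A few compounds are considered here, and "the series" means these few. Any claim that something is new, unique, unknown or untested is made for them only; others in the source may bear on it.

In a functional assay on THP-1 cells (Homo sapiens) for cytotoxicity, read by MTT assay, with a stated time of 24 h (on this read-out lower numbers stand for stronger inhibition and higher numbers for weaker inhibition), compound 1 (`COc1ccc(/C=C2\CC[C@H]3C(C)(C)CCC[C@]3(C)[C@H]2CCC(C)CC(=O)O)cc1`) gives > 200000 nM, which is a limit of the assay and not a number. Its true value is therefore unknown, and any step that starts from it is only partly defined. Compound 2 (`COc1ccc(/C=C2\CC[C@H]3C(C)(C)CCC[C@]3(C)[C@H]2CCC(C)CC(=O)O)cc1OC`) carries an extra methoxy on the aromatic ring and gives 178000 nM.

Compound 3 (`CC(CC[C@H]1/C(=C/c2ccc(Br)cc2)CC[C@H]2C(C)(C)CCC[C@]12C)CC(=O)O`) keeps the shared core and the acid chain of compound 1 but has bromo in place of methoxy on an aromatic carbon, para to a large group: bromo in place of methoxy on an aromatic carbon. The change is the swap of 4-methoxyphenyl for 4-bromophenyl.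

Within the data shown here, only one measured step touches this ring: an at least 1.1-fold lower number from compound 1 to compound 2 (0.05 log units; that floor lies within the scatter). That step adds a methoxy rather than replacing one, so it is a loose guide, but it gives no sign that changes on this ring move the number much in this assay. A step beyond the scatter is therefore not expected, and any shift would most likely be towards a slightly lower number.

The expected step is an at least 1.3-fold lower number from compound 1 to compound 3 (0.12 log units; that floor lies within the scatter). For compound 3 the estimated value is 150000 nM, within an expected range from 60000 nM to 300000 nM.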

Compound 3, half-maximal inhibitory concentration: > 200000 nM
Compound 3 ended at the assay's limit (the forecaster's own chance of this, stated with the estimate: 40%); middle value at least 1.3-fold (0.12 log units) from the limit.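

In this assay compound 3 gives > 200000 nM, which is a limit of the assay and not a number, so a para bromo, like the para methoxy of compound 1, yields no measured value on this ring. Set against the only true number in the series, the change gives an at least 1.1-fold higher number from compound 2 to compound 3 (0.05 log units; that floor lies within the scatter), so the data do not separate these two compounds. The step between the two limits cannot be read, and no size can be given for the change from 4-methoxyphenyl to 4-bromophenyl: the limit of > 200000 nM in this assay, at which 2 of the 3 values shown sit.

What the compounds shown leave open is whether an amine or a hydroxy group in the same place on the ring would give a readable number in this assay. Also open, from the compounds shown here alone, is whether an amide or a methyl ester in place of the carboxylic acid, on the same shared core, would give a value clearly away from the limit.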